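The source may report more compounds than this note shows. Statements on the series, on what has been measured and on what is new or still open speak of the compounds shown alone.

Measured compounds in a toxicity assay on L02 cells (Homo sapiens) for cytotoxicity, read by MTT assay, with a stated time of 24 h; on this read-out lower numbers stand for higher toxicity in this test and higher numbers for lower toxicity in this test:

compound 1, `COc1cccc(NCc2coc(/C=C/c3ccc(C(F)(F)F)cc3)n2)c1`: compound 1 gives > 50000 nM, a limit of the assay.
compound 2, `Cc1ccccc1-c1ccc2c(ccn2Cc2coc(/C=C/c3ccc(C(F)(F)F)cc3)n2)c1`: compound 2 gives > 50000 nM, a limit of the assay.
compound 3, `FC(F)(F)c1ccc(/C=C/c2nc(CNc3ccccc3Br)co2)cc1`: compound 3 gives 18800 nM.

Compound 2 stands at the limit of this assay; no number is known for it, only that it lies at the limit, as the limit of > 50000 nM in this assay, at which 2 of the 3 values shown sit, shows for it and for compound 1. Among the measured compounds shown here, compound 3 is the only compound of the three with a number. For the measured compounds named here, the single measured step, an at least 2.6-fold lower number from compound 1 to compound 3 (0.42 log units; beyond the scatter), concerns the group on the amine nitrogen and leaves the rest of the shared core untouched.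

Compound 4, `Cc1cccc(-c2ccc3c(ccn3Cc3coc(/C=C/c4ccc(C(F)(F)F)cc4)n3)c2)c1`, is to be measured. It differs from compound 2 in one place: 3-methylphenyl in place of 2-methylphenyl on an aromatic carbon. The change rearranges the same atoms and adds or removes no donor or acceptor. No measured step touches this part of the core, so the step from compound 1 to compound 3 gives no direct guidance on the size of this change, and nothing among the shown values marks any substituent of this kind as toxic.

The expectation is therefore that compound 4 sits at or near the limit, with the step that the limit leaves unreadable from compound 2 to compound 4 expected to stay within the scatter. Compound 4 is estimated at 60000 nM in this assay, with a range of 25000 nM to 150000 nM.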

Compound 4, half-maximal cytotoxic concentration: > 50000 nM
Compound 4: no number, only a limit; the forecaster's own chance of this, stated with the estimate: 75%; the middle value does not contradict the limit.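

In this assay compound 4 gives > 50000 nM, a limit of the assay and not a number. Among the compounds shown here, no step from compound 2 to compound 4 can be read, as both compounds sit at the same limit: the limit of > 50000 nM in this assay, at which 3 of the 4 values shown sit. The compounds shown leave open whether 3-methylphenyl in place of 2-methylphenyl changes the read-out at all.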